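Fluoro for hydrogen on the phenyl of compound 3

A few compounds are considered here, and "the series" means these few. Any claim that something is new, unique, unknown or untested is made for them only; others in the source may bear on it.

Measured so far in a functional assay, read by spectrophotometry, with a stated time of 15 min, tested at 100 ug/mL; on this read-out lower numbers stand for a weaker effect and higher numbers for a stronger effect at the one concentration tested:
compound 1 `Cc1ccc(-c2csc(N/N=C/c3cccs3)n2)cc1`, 91%
compound 2 `Fc1ccc(-c2csc(N/N=C/c3cccs3)n2)cc1`, 92.4%
compound 3 `Clc1ccc(/C=N/Nc2nc(-c3ccccc3)cs2)c(Cl)c1`, 87.4%

Compound 3 holds the lowest of the three numbers in this assay, yet its gaps to compound 1 and to compound 2 are both within the scatter, so no order among the three can be claimed; all three read high.

Compound 4 `Fc1ccc(-c2csc(N/N=C/c3ccc(Cl)cc3Cl)n2)cc1` is not yet measured. It differs from compound 3 in one place: fluoro in place of hydrogen on an aromatic carbon.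

Going by the values given here, the only measured step that touches the same place is a number 1.4 percentage points higher from compound 1 to compound 2 (within the scatter). That step exchanged methyl for fluoro rather than hydrogen for fluoro, so it bears on the present change only loosely, but it shows that fluoro at this position, on a compound with the same core, leaves the read-out in this assay essentially unchanged. Among the compounds with values here, no measured pair shows hydrogen against fluoro here.

Compound 4 is therefore expected to sit close to compound 3, with a step of a number 1.6 percentage points higher from compound 3 to compound 4 (within the scatter) that is not expected to exceed the scatter in either direction. Compound 4 is estimated at 89%, with a range from 80% to 96%.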

Compound 4, a percentage reported as inhibition, at one concentration (the size of the read-out at that concentration, not a potency): 95.6%
Compound 4: the middle estimate sits 6.6 percentage points below what was measured; the measured number falls inside the stated range.
By their numbers in this assay, from the lowest: compounds 3, 1, 2 and 4 (each within the scatter of the next).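

Going by these compounds alone, this pair is the first direct reading of hydrogen against fluoro on this aromatic carbon: in this assay, going from phenyl to 4-fluorophenyl gives a number 8.2 percentage points higher from compound 3 to compound 4 (within the scatter). The step therefore does not separate the two compounds, so the fluoro group is tolerated here, with the high read-out kept, on a compound whose other end carries the dichlorinated ring of compound 3, and not only on the compounds of the earlier methyl and fluoro pair. No measurement available here offers an explanation for the size of this step.

The compounds shown leave open whether an amine or a carboxylic acid on this aromatic carbon would move the read-out in this assay beyond the scatter, and whether hydrogen against fluoro reads the same way with the other end of compound 2. Since every number comes from the one concentration tested, they also leave open whether any of these compounds differ in potency, which a single reading at that concentration cannot tell.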